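The source may report more compounds than this note shows. Statements on the series, on what has been measured and on what is new or still open speak of the compounds shown alone.

Compound 1 `CCCN1C(=O)CCC1(O)c1cccc(C(F)(F)F)c1`: 150 mg/kg
Compound 2 `CN(C)C(=O)CCC(=O)c1cccc(C(F)(F)F)c1`: > 37.5 mg/kg

Both compounds were tested in a functional assay on the whole organism with Mus musculus as the target; a higher number here means that more compound is needed for the effect, a lower number that less compound is needed. Among the measured compounds shown here, compound 1, at 150 mg/kg, gives the only exact number. Compound 2 stands at a limit and not at a number: > 37.5 mg/kg.

Compound 3 `CN1CCN(C(=O)CCC(=O)c2cccc(C(F)(F)F)c2)CC1` keeps the core of compound 2 but carries 4-methylpiperazin-1-yl in place of dimethylamino on a carbonyl carbon. For the measured compounds named here, no pair of measured compounds shows this change, so the expectation is rough. The expected change, a step that the limit leaves unreadable from compound 2 to compound 3, is no larger than the usual scatter. Compound 3 is estimated at 60 mg/kg, with an expected range of 25 mg/kg to 150 mg/kg.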

Compound 3, dose for half-maximal effect: > 37.5 mg/kg
Compound 3: a limit, no number (the forecaster's own chance of this, stated with the estimate: 40%); the middle value lies beyond the limit too.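

Compound 2 and compound 3 both give a limit rather than a number, so no step can be read between them: the limit of > 37.5 mg/kg in this assay, at which 2 of the 3 values shown sit.

The compounds shown leave open whether 4-methylpiperazin-1-yl in place of dimethylamino on a carbonyl carbon changes the dose needed at all.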